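The source may hold more compounds than are shown below. What is called first, only, known or untested is meant among the compounds shown, and "the series" means these compounds.

In an ADME assay on microsomes from liver (Mus musculus) for metabolic stability, read by LC-MS, using NADPH, with a stated time of 60 min, tested at 1 uM (a lower number here means that the compound disappears faster, a higher number that the compound lasts longer), compound 1 (`O=S(=O)(c1cccc(C(F)(F)F)c1)n1ccc2ccc(-c3cc(F)cc(OC(F)F)c3)cc21`) gives 0.652 h and compound 2 (`O=C(O)CCC1Cc2ccc(-c3cc(F)cc(OC(F)F)c3)cc2N1S(=O)(=O)c1cccc(C(F)(F)F)c1`) gives 1.02 h. These two values lie within the usual scatter of each other, so on these numbers compound 2 cannot be told apart from compound 1. Compound 3 (`O=C(CC1Cc2ccc(-c3cc(F)cc(OC(F)F)c3)cc2N1S(=O)(=O)c1cccc(C(F)(F)F)c1)N1CCS(=O)(=O)CC1`) keeps the rest of compound 2 but carries (1,1-dioxothiomorpholin-4-yl)carbonyl in place of carboxymethyl on a saturated chain carbon bound to a saturated ring carbon. For the measured compounds named here, no measured pair shows what this exchange does to the half-life, so the direction remains open. The starting point is compound 2 at 1.02 h, and no change beyond the scatter is expected in this assay. The estimated step of a 1.2-fold higher number from compound 2 to compound 3 (0.07 log units; within the scatter) is therefore small. For compound 3 the expected half-life is 1.2 h, with an estimated range from 0.5 h to 3 h.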

Compound 3, half-life: 0.0333 h
Compound 3: the middle estimate sits 36-fold (1.56 log units) above what was measured, and the stated range ends above it.
By their numbers in this assay, from the lowest: compound 3; then compounds 1 and 2 (each within the scatter of the next).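

In this assay, for the compounds shown here, the exchange of carboxymethyl for (1,1-dioxothiomorpholin-4-yl)carbonyl gives a 31-fold lower number from compound 2 to compound 3 (1.49 log units; beyond the scatter) and so provides the first one-place comparison at this saturated chain carbon. It shows that the half-life can respond strongly to the group placed here, and that this particular exchange shortens it well beyond the usual scatter. Nothing available explains the size of this step.

A single exchange replaces the carboxymethyl group with an entirely different one, so the compounds shown cannot separate the contribution of the amide carbonyl from that of the ring and its sulfur dioxide unit. A morpholine amide or a dimethyl amide at the same place would test whether the short half-life stays when the ring is altered or removed.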